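A few compounds are considered here, and "the series" means these few. Any claim that something is new, unique, unknown or untested is made for them only; others in the source may bear on it.

Measured in a functional assay on P388 cells (Mus musculus) for cytotoxicity; a higher number here means a weaker inhibitor, a lower number a stronger inhibitor:
- compound 1 `C=C[C@@H]1NC(=O)[C@@H](C)NC(=O)[C@@H]2Cc3ccc(OC)c(c3)Oc3ccc(cc3)C[C@@H](C(=O)N2C)N(C)C(=O)[C@H](C)NC(=O)[C@H](Cc2ccc(OC)cc2)N(C)C1=O`: 25.7 nM
- compound 2 `CCc1ccc(C[C@H]2C(=O)N[C@@H](C)C(=O)N(C)[C@H]3Cc4ccc(cc4)Oc4cc(ccc4OC)C[C@@H](C(=O)N[C@H](C)C(=O)N[C@@H](C)C(=O)N2C)N(C)C3=O)cc1`: 9.33 nM

Of these two, compound 2 gives the lower number and so is the stronger inhibitor, and its gap to compound 1 lies beyond the scatter. Going by the values given here, the two values are the only measurements so far, and no measured pair differs in one place. The series therefore offers no direct size for any single change.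

Compound 3 `COc1ccc(C[C@H]2C(=O)N[C@@H](C)C(=O)N(C)[C@H]3Cc4ccc(cc4)Oc4cc(ccc4OC)C[C@@H](C(=O)N[C@H](C)C(=O)N[C@@H](C)C(=O)N2C)N(C)C3=O)cc1O` has not yet been measured. It carries 3-hydroxy-4-methoxyphenyl in place of 4-ethylphenyl on a saturated chain carbon bound to a saturated ring carbon. In this assay a moderate move towards a higher number is expected, though this is a judgement with little data behind it. Compound 2 at 9.33 nM holds the lowest number seen, and the only other reference point is compound 1 at 25.7 nM. The expected change is a 3.2-fold higher number from compound 2 to compound 3 (0.51 log units; beyond the scatter), towards a weaker inhibitor. Compound 3 is estimated at 30 nM, with an expected range of 10 nM to 100 nM.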

Compound 3, half-maximal inhibitory concentration: 214 nM
For compound 3 the middle estimate is 7.1-fold (0.85 log units) below the measured one; measured number outside the range, above it.
By their numbers in this assay, from the lowest: compound 2; then compound 1; then compound 3.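

In this assay the saturated chain carbon bound to a saturated ring carbon proves to be a place where the substituent matters: 3-hydroxy-4-methoxyphenyl in place of 4-ethylphenyl gives a 23-fold higher number from compound 2 to compound 3 (1.36 log units; beyond the scatter) and moves the series towards a weaker inhibitor. Going by these compounds alone, this is the only single-place step, so it gives the first direct size for any one change, and that size is large. The step exchanges an ethyl group for a hydroxy and a methoxy group at once, so the two structural changes cannot be separated, and no measurement shown explains the loss.

The compounds shown leave open whether the loss follows the hydroxy group, the methoxy group or the removal of the ethyl group, which 3-hydroxyphenyl and 4-ethyl-3-hydroxyphenyl at this place would help to separate. They also leave open whether any replacement can go beyond 4-ethylphenyl in this assay, for instance a longer chain as in 4-propylphenyl, or an amine as in 4-aminophenyl.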